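Thiophene for furan on a chloro indole core

The source may report more compounds than this note shows. Statements on the series, on what has been measured and on what is new or still open speak of the compounds shown alone.

Measured so far in an ADME assay on microsomes from liver (Homo sapiens) for metabolic stability, read by LC-MS, using NADPH, tested at 3 uM; a higher number here means that the compound lasts longer, a lower number that the compound disappears faster:
compound 1 `Cc1ccc2c(C(CC(F)(F)F)c3cccs3)c(-c3ccccc3)[nH]c2c1` gives 1.8 h
compound 2 `Cc1ccc2c(C(CC(F)(F)F)c3ccco3)c(-c3ccccc3)[nH]c2c1` gives 0.985 h
compound 3 `FC(F)(F)CC(c1ccco1)c1c(-c2ccccc2)[nH]c2cc(Cl)ccc12` gives 1.07 h

Compound 2 and compound 1 differ only in one place, (thiophen-2-yl in place of furan-2-yl on a saturated chain carbon bound to an aromatic carbon and a saturated chain carbon), and this change gave a 1.8-fold higher number from compound 2 to compound 1 (0.26 log units; within the scatter). Compound 3 carries a different core from compound 2, the difference being (chloro in place of methyl on an aromatic carbon), and this change gave a 1.1-fold higher number from compound 2 to compound 3 (0.04 log units; within the scatter). Compound 4 `FC(F)(F)CC(c1cccs1)c1c(-c2ccccc2)[nH]c2cc(Cl)ccc12` has not yet been measured in this assay. It stands to compound 3 as compound 1 stands to compound 2: the change is thiophen-2-yl in place of furan-2-yl on a saturated chain carbon bound to an aromatic carbon and a saturated chain carbon, on the same kind of position, so it is the same change made on the core of compound 3. For compound 4 the step from compound 3 is expected to resemble the earlier one, a 1.7-fold higher number from compound 3 to compound 4 (0.23 log units; within the scatter), because compound 2 to compound 1 gave a 1.8-fold higher number from compound 2 to compound 1 (0.26 log units; within the scatter) and the core change itself gave only a 1.1-fold higher number from compound 2 to compound 3 (0.04 log units; within the scatter). On this basis compound 4 is estimated to reach 1.8 h in this assay, with a range from 0.9 h to 3.5 h.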

Compound 4, half-life: 2.62 h
The estimate for compound 4 lay 1.5-fold (0.16 log units) below the measured number, within the range that was stated.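

In this assay, thiophen-2-yl in place of furan-2-yl on the core of compound 3 gave a 2.4-fold higher number from compound 3 to compound 4 (0.39 log units; beyond the scatter), and the size of this step matched that of the same change on the core of compound 2: the same change on two cores in this assay, a 1.8-fold higher number (0.26 log units; within the scatter) from compound 2 to compound 1 and a 2.4-fold higher number (0.39 log units; beyond the scatter) from compound 3 to compound 4, 1.3-fold (0.13 log units) apart, within the scatter of two such steps. Chloro in place of methyl gave a 1.5-fold higher number from compound 1 to compound 4 (0.16 log units; within the scatter), and this change also read alike on the two furan and thiophene partners: the same change on two cores in this assay, a 1.1-fold higher number (0.04 log units; within the scatter) from compound 2 to compound 3 and a 1.5-fold higher number (0.16 log units; within the scatter) from compound 1 to compound 4, 1.3-fold (0.13 log units) apart, within the scatter of two such steps. Among the compounds shown here, the four compounds thus show that both changes carried between these two cores without a detectable difference, but with only two cores and one of the thiophene steps within the scatter, they do not show how far this holds on other cores or why the half-life differs.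

Going by these compounds, all four compounds keep the same phenyl group and the same fluorinated chain, so it remains open whether the step would hold with an amine, a carboxylic acid or a longer chain in that region. On these data alone, whether the step holds in any other assay also remains open.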